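A few compounds are considered here, and "the series" means these few. Any claim that something is new, unique, unknown or untested is made for them only; others in the source may bear on it.

Measured compounds in an ADME assay on the whole organism with Oryza sativa as the target, tested at 0.1 uM; on this read-out lower numbers stand for a stronger effect and higher numbers for a weaker effect at the one concentration tested:
compound 1 `CCc1ccc(NC(=O)N[C@H](C)c2ccccc2)cc1` gives 95%
compound 2 `CCc1ccc(NC(=O)N[C@@H](C)c2ccccc2)cc1` gives 99%
compound 3 `CC(C)c1cccc(NC(=O)N[C@@H](C)c2ccccc2)c1` gives 95%

Compound 2 carries the top number of the three, but its gap to compound 1 and its gap to compound 3 are each within the scatter, so the three numbers read as one level. Within the data shown here, the only step measured between two compounds that differ in one place is a number 4 percentage points higher from compound 1 to compound 2 (within the scatter); it rests on the fact that compounds 1 and 2 differ only in the configuration as drawn and therefore carries no information about a change of a substituent on the ring. Among the measured compounds shown here, compound 3 differs from compound 2 in two places and gives no step.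

Compound 4 `CCOC(=O)c1ccc(NC(=O)N[C@@H](C)c2ccccc2)cc1` is the unmeasured partner of compound 2: ethoxycarbonyl in place of ethyl on an aromatic carbon. For the measured compounds named here, no measured step covers a change of this kind, so the data give no basis for a direction. Every measured number lies high, and the spread among them stays within the scatter. On that basis compound 4 is expected to stay near the measured level, a number 4 percentage points lower from compound 2 to compound 4 (within the scatter). The estimate for compound 4 in this assay is 95%, with a range from 80% to 100%.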

Compound 4, a percentage reported as activity, at one concentration (the size of the read-out at that concentration, not a potency): 99%
Beside the measured number, compound 4's estimate is 4 percentage points below it, and the stated range covers the measured number.
By their numbers in this assay, from the lowest: compounds 1, 3, 2 and 4 (each within the scatter of the next).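

In this assay, among these compounds, ethoxycarbonyl in place of ethyl on an aromatic carbon, para to a large group, is the first change of a ring substituent that can be read as a step, and it gives no change at the digits printed from compound 2 to compound 4 (within the scatter) in this series. This position therefore takes a group of 5 heavy atoms with 2 hydrogen-bond acceptors, where ethyl has 2 heavy atoms and 0 acceptors, without a step beyond the scatter. Nothing at hand bears on why this change leaves the read-out flat.

All the numbers shown still read as one level, so no step yet shows that this position can move the read-out at all. As far as these compounds go, whether an amine or a carboxylic acid at this position, or a longer chain in place of ethyl, would produce such a step stays open.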